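The source may hold more compounds than are shown below. What is called first, only, known or untested is meant among the compounds shown, and "the series" means these compounds.

Compound 1 `COc1ccc(C(=O)/C=C/c2ccc(C(=O)Nc3cc([N+](=O)[O-])ccc3O)cc2)c(O)c1` belongs to a small set of three compounds that share one core and differ in the group attached to it. In an ADME assay on SH-SY5Y cells (Homo sapiens) for cytotoxicity, read by MTT assay, with a stated time of 48 h (on this read-out lower numbers stand for stronger inhibition and higher numbers for weaker inhibition), compound 1 gives > 100000 nM, which is a limit of the assay and not a measured number. Compound 2 `COc1ccc(C(=O)/C=C/c2cc(Br)c(OCc3ccccc3)c(OC)c2)c(O)c1` also gives only a limit in this assay, > 100000 nM. Compound 3 `COc1ccc(C(=O)/C=C/c2ccc(OCCCOc3ccccc3)c(OC)c2)c(O)c1` likewise stands at a limit in this assay, > 100000 nM. For the measured compounds named here, all three values therefore sit at the limit of > 100000 nM in this assay, at which 3 of the 3 values shown sit, and no step between measured compounds can be read from them; where compound 1 stands relative to compound 2 and compound 3 cannot be told beyond the fact that all three reach the same limit.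

Compound 4 `COc1ccc(C(=O)/C=C/c2ccc(C(=O)Nc3ccccc3OC)cc2)c(O)c1` has not yet been measured in this assay. It differs from compound 1 by 2-methoxyphenyl in place of 2-hydroxy-5-nitrophenyl on an amide-type nitrogen. Going by the values given here, no measured pair shows what this change does in this assay. Compound 4 is expected to give 100000 nM, within 40000 nM to 300000 nM, because compound 1 and both other compounds rest at the limit of > 100000 nM in this assay, at which 3 of the 3 values shown sit. The expected step of a number no higher from compound 1 to compound 4 (the limit leaves the size open) is accordingly none beyond the usual scatter, with a real chance that the assay again reports only a limit for compound 4.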

Compound 4, half-maximal inhibitory concentration: > 100000 nM
Compound 4: only a limit was reported; the forecaster's own chance of this, stated with the estimate: 70%; the middle value sits exactly at the limit.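

For the compounds shown here, compound 4, like compound 1, gives only a limit of the assay and not a number in this assay, and no step between compound 1 and compound 4 can be read: the limit of > 100000 nM in this assay, at which 4 of the 4 values shown sit. The compounds shown leave open how far any of these values lies beyond that limit, and whether any group on the shared core would give a measured number.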